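This account rests on a few compounds, and the source may have more. Where it says the series, first, only, none or still open, it means among the compounds named here.

Measured in an assay on ileum with muscarinic acetylcholine receptor M3 (Cavia porcellus) as the target; on this read-out higher numbers stand for weaker inhibition and lower numbers for stronger inhibition:
- compound 1 `CCN(CC)CCC(c1ccccc1)c1ccccc1`: 197 nM
- compound 2 `c1ccc(C(CCN2CCCCC2)c2ccccc2)cc1`: 69.6 nM
- compound 3 `CC(C)c1nccn1CCC(C(N)=O)(c1ccccc1)c1ccccc1`: 1.8 nM

Compound 3 stands lowest of the three numbers in this assay; compound 2 and compound 1 both stand well above it, beyond the scatter. Compound 4 `Cc1cn(CCC(C(N)=O)(c2ccccc2)c2ccccc2)cn1` differs from compound 3 by 4-methyl-1H-imidazol-1-yl in place of 2-isopropyl-1H-imidazol-1-yl on a saturated chain carbon, three bonds along the chain from two aromatic carbons and a carbonyl carbon. Going by the values given here, the single measured step, a 2.8-fold lower number from compound 1 to compound 2 (0.45 log units; beyond the scatter), concerns the amine at the chain end and not the imidazole substituents, so no step in the set speaks directly to this change. With nothing to anchor a shift, the expectation is a step of a 1.7-fold higher number from compound 3 to compound 4 (0.22 log units; within the scatter) from compound 3 to compound 4, that is no step beyond the scatter, with a slight lean towards a higher number. Compound 4 is therefore estimated at 3 nM in this assay, in the range 1 nM to 12 nM.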

Compound 4, antagonist equilibrium constant: 10.1 nM
Beside the measured number, compound 4's estimate is 3.4-fold (0.53 log units) below it; measured number inside the range.
By their numbers in this assay, from the lowest: compound 3; then compound 4; then compound 2; then compound 1.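

In this assay the substituted imidazole on this saturated chain carbon affects the read-out: the swap gives a 5.6-fold higher number from compound 3 to compound 4 (0.75 log units; beyond the scatter) with the rest of the molecule unchanged. Going by these compounds alone, the earlier step concerned only the amine at the chain end, so this is the first reading on the imidazole substituent. No measured evidence here accounts for the shift.

The swap changes both the alkyl group and its ring position, so the two remain unseparated. A 2-methyl-1H-imidazol-1-yl group would separate them, and the unsubstituted 1H-imidazol-1-yl group would give a baseline.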